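Methylating a ring hydroxyl: cytotoxicity notes on four compounds

This account rests on a few compounds, and the source may have more. Where it says the series, first, only, none or still open, it means among the compounds named here.

So far compound 1, compound 2 and compound 3 have been run in a functional assay on PC-12 cells (Rattus norvegicus) for cytotoxicity, read by MTT assay, with stated times of 2 h and 4 h, tested at 16 ug/mL; on this read-out higher numbers stand for a stronger effect at the one concentration tested and lower numbers for a weaker effect. Compound 1 `COc1cc2c(c(OC)c1O)C(=O)[C@H](O)[C@@H](c1ccc(O)cc1)O2` gives 13.4%. Compound 2 `COc1ccc([C@@H]2Oc3cc(OC)c(O)c(OC)c3C(=O)[C@@H]2O)cc1OC` gives 19.8%, and compound 3 `COc1cc([C@@H]2Oc3cc(OC)c(O)c(OC)c3C(=O)[C@@H]2O)ccc1O` gives 0.5%. The numbers of compound 1 and compound 2 lie within the scatter of each other, while the gap from compound 3 to compound 1 lies beyond it.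

For the measured compounds named here, the one single-point step measured so far runs from compound 3 to compound 2: a number 19.3 percentage points higher from compound 3 to compound 2 (beyond the scatter). The change there is methyl in place of hydrogen on an oxygen on an aromatic ring, on an oxygen on an aromatic ring whose other neighbours are aromatic carbon. Compound 1 and compound 3 differ in more than one place, and the difference between their two cores is not broken down here.

Compound 4 `COc1cc2c(c(OC)c1OC)C(=O)[C@H](O)[C@@H](c1ccc(O)cc1)O2` has not yet been measured in this assay. It differs from compound 1 by methyl in place of hydrogen on an oxygen on an aromatic ring, the same change, at the same kind of place, as the measured step from compound 3 to compound 2. On that single precedent the step from compound 1 to compound 4 is expected to be a number 16.6 percentage points higher from compound 1 to compound 4 (beyond the scatter), an increase of similar size to the measured one, though resting on one pair only and on a different core. For compound 4 the number expected in this assay is therefore 30%, with a range from 14% to 46%.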

Compound 4, a percentage reported as activity, at one concentration (the size of the read-out at that concentration, not a potency): 5.1%
For compound 4 the middle estimate is 24.9 percentage points above the measured one, and the stated range ends above it.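

Notes on the new pair: in this assay, methyl in place of hydrogen on an oxygen on an aromatic ring gives a number 8.3 percentage points lower from compound 1 to compound 4 (within the scatter), so on the core of compound 1 this change has no effect that can be told from the usual scatter. Its size and direction therefore do not carry over unchanged from one core to the other in this series, and the earlier pair is not a reliable guide for the core of compound 1: the same change on two cores in this assay, a number 19.3 percentage points higher (beyond the scatter) from compound 3 to compound 2 and a number 8.3 percentage points lower (within the scatter) from compound 1 to compound 4, 27.6 percentage points apart, beyond the scatter of two such steps

This rests on two pairs, each read once at a single concentration, so it shows that the hydroxy to methoxy change depends on its setting here, but it gives no general rule and does not show which structural difference between the pairs accounts for the gap.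

The compounds shown leave open how this assay would read with a longer chain on that oxygen, such as ethoxy, or with an amine or a carboxylic acid at the same place. For the compounds shown here, they also leave open whether the same hydroxy to methoxy change on a third core would resemble the step seen with compound 2 or the one seen with compound 4.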